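The compounds below may be only part of what the source reports. "The series", "measured", "known", "first", "only" and "open" are said of these compounds alone.

In a functional assay on ECa-109 cells for inhibition, with ECa-109 cell line (Homo sapiens) as the target, read by sulforhodamine B assay (a higher number here means a weaker inhibitor, a lower number a stronger inhibitor), compound 1 `O=C1C=C(N2CCC2)C(=O)c2c1nc1n2[C@H]2OC[C@@H](O)[C@H]2OC1` gives only a limit, > 16000 nM, one of the two values sitting at the limit of > 16000 nM in this assay, at which 1 of the 2 values shown sits. Compound 2 `Cc1ccc(NC2=CC(=O)c3c(nc4n3[C@H]3OC[C@@H](O)[C@H]3OC4)C2=O)cc1` likewise gives only a limit in this assay, > 4000 nM, and so stands at the limit of > 4000 nM in this assay, at which 1 of the 2 values shown sits. Going by the values given here, no step between measured compounds can be read from these two limits. Compound 3 `O=C1C(Nc2cccc(F)c2)=CC(=O)c2c1nc1n2[C@H]2OC[C@@H](O)[C@H]2OC1` differs from compound 2 by 3-fluorophenyl in place of 4-methylphenyl on an amine nitrogen. The step that the limit leaves unreadable from compound 2 to compound 3 is expected to stay within the usual scatter, as neither anchor offers a number to build on. Compound 3 is expected to give about 8000 nM in this assay, within 2500 nM to 30000 nM, with a substantial chance that only a limit is reported again.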

Compound 3, half-maximal inhibitory concentration: 2370 nM
For compound 3 the middle estimate is 3.4-fold (0.53 log units) above the measured one; the measured number lies below the stated range.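

In this assay, going by these compounds alone, compound 3 gives 2370 nM, the first actual number for an arylamino group at this position of the shared core. The change to 3-fluorophenyl gives an at least 1.6-fold lower number from compound 2 to compound 3 (0.22 log units; that floor lies within the scatter), so its true size stays unfixed. That step rests on the limit held by compound 2: the limit of > 4000 nM in this assay, at which 1 of the 3 values shown sits.

The compounds shown do not separate the loss of the methyl group from the arrival of the fluorine. Going by these compounds, how phenyl, 4-fluorophenyl or benzyl would read on this amine nitrogen stays open.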